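Bromo-to-methyl exchange on the fused ring: expected growth inhibition

The compounds below may be only part of what the source reports. "The series", "measured", "known", "first", "only" and "open" are said of these compounds alone.

Compound 1 `O=c1cc(-c2ccccc2)oc2cc(N3COc4c(cccc4[N+](=O)[O-])C3)ccc12` gives 1.96% in a functional assay on MCF7 cells (Homo sapiens) for inhibition, read by MTT assay, with a stated time of 48 h, tested at 15 ug/mL; a lower number here means less inhibition of growth, a higher number more inhibition of growth at the concentration tested.
Compound 2 `O=c1cc(-c2ccccc2)oc2cc(N3COc4c(Br)cccc4C3)ccc12` gives 5.64% in this assay.

Compound 2 and compound 1 lie within the scatter of each other; the step of a number 3.7 percentage points higher from compound 1 to compound 2 (within the scatter) is the only one measured so far. Compound 3 `Cc1cccc2c1OCN(c1ccc3c(=O)cc(-c4ccccc4)oc3c1)C2` differs from compound 2 by methyl in place of bromo on an aromatic carbon. That change touches the same aromatic carbon as the measured step, which showed no shift beyond the scatter, so a step of at most scatter size is expected in this assay, with no preferred direction. Compound 3 is estimated at 5% (range 0% to 15%), a change of a number 0.6 percentage points lower from compound 2 to compound 3 (within the scatter) expected.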

Compound 3, percent growth inhibition at one concentration: 54.9%
For compound 3 the middle estimate is 49.9 percentage points below the measured one, outside the stated range (above it).
By their numbers in this assay, from the lowest: compounds 1 and 2 (each within the scatter of the next); then compound 3.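

In this assay this aromatic carbon proves sensitive to the choice of substituent: methyl in place of bromo gives a number 49.3 percentage points higher from compound 2 to compound 3 (beyond the scatter) and methyl in place of nitro gives a number 52.9 percentage points higher from compound 1 to compound 3 (beyond the scatter) on the same core. The closeness of the bromo and nitro compounds therefore did not mark the position as tolerant of any change, and among these three groups methyl alone stands apart. Nothing at hand accounts for this separation. Going by these compounds, whether an ethyl chain, a methoxy group or an amine on this carbon would keep the growth inhibition of compound 3 remains open.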